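Removing a Fluoro: Oral Bioavailability Expected to Hold

This account rests on a few compounds, and the source may have more. Where it says the series, first, only, none or still open, it means among the compounds named here.

Compound 2 `CN1CCC(=C(F)c2cccc(NC(=O)c3ccc(Cl)cc3F)n2)CC1` was measured in an ADME assay on the whole organism (Rattus norvegicus, strain Sprague-Dawley) for pharmacokinetics, read by LC-MS, with a stated time of 24 h, at a dose of 5 mg/kg by the oral route (a higher number here means that a larger share of the oral dose reaches the circulation, a lower number that a smaller share of the oral dose reaches the circulation), where compound 2 gives 26.2%. Compound 1 `CN1CCC(=C(F)c2cccc(NC(=O)c3ccc(F)cn3)n2)CC1` gives 23.7% in this assay. Among the two measured compounds, compound 2 has compound 1 as its only neighbour, and the step of a number 2.5 percentage points higher from compound 1 to compound 2 (within the scatter) is within the scatter, so the two cannot be told apart on these numbers. Compound 3 `CN1CCC(=C(F)c2cccc(NC(=O)c3ccc(Cl)cc3)n2)CC1` is not yet measured. Among the compounds with values here, the change hydrogen in place of fluoro on an aromatic carbon touches the 4-chloro-2-fluorophenyl ring alone; no measured step removes a fluoro from this ring, and the only known step, the exchange of the 5-fluoropyridin-2-yl ring for the 4-chloro-2-fluorophenyl ring, stayed within the scatter. Nothing here points to a shift beyond the scatter in either direction. For compound 3 the expected step is a number 1.2 percentage points lower from compound 2 to compound 3 (within the scatter). Compound 3 is therefore estimated at 25%, with a range from 12% to 40%.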

Compound 3, oral bioavailability: 39%
Compound 3: the middle estimate sits 14 percentage points below what was measured, and the stated range covers the measured number.
By their numbers in this assay, from the lowest: compounds 1 and 2 (each within the scatter of the next); then compound 3.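

In this assay, within the data shown here, this position on the ring proves sensitive to a single atom: hydrogen in place of fluoro on the aromatic carbon ortho to the large group gives a number 12.8 percentage points higher from compound 2 to compound 3 (beyond the scatter), the only step so far from compound 2 that lies beyond the scatter. Against compound 1, 4-chlorophenyl in place of 5-fluoropyridin-2-yl gives a number 15.3 percentage points higher from compound 1 to compound 3 (beyond the scatter), whereas the exchange that kept the fluoro gave a number 2.5 percentage points higher from compound 1 to compound 2 (within the scatter), so the two ring exchanges now read differently. No measurement at hand accounts for this difference.

The compounds shown leave open whether a methyl, a methoxy or an amine on the same carbon would read like the hydrogen or like the fluoro. They also leave open whether the step from fluoro to hydrogen holds when the chloro group is replaced by a nitrile.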